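The source may report more compounds than this note shows. Statements on the series, on what has been measured and on what is new or still open speak of the compounds shown alone.

Compound 1 `O=C1N=C(N2N=C(c3ccccc3)CC2c2ccccc2O)S/C1=C1/C(=O)Nc2ccc(Br)cc21`: 290 nM
Compound 2 `COc1ccc(C2CC(c3ccccc3)=NN2C2=NC(=O)/C(=C3\C(=O)Nc4ccccc43)S2)cc1`: 1520 nM

Both compounds were tested in a functional assay on cells (Cancer cell lines, Homo sapiens) for cytotoxicity, read by sulforhodamine B assay, with a stated time of 48 h; on this read-out lower numbers stand for stronger inhibition of growth and higher numbers for weaker inhibition of growth. Compound 1 gives 290 nM, and compound 2 gives 1520 nM, the higher of the two numbers; compound 1 lies lower by a gap beyond the usual scatter. Compound 3 `COc1ccc(C2CC(c3ccccc3)=NN2C2=NC(=O)/C(=C3\C(=O)Nc4ccc(Br)cc43)S2)cc1` has not yet been measured. It differs from compound 2 in a single place: bromo in place of hydrogen on an aromatic carbon. Among the compounds with values here, no two measured compounds differ in just this one place, so the size of such a change cannot be read off directly. Even so, a shift to a lower number, beyond the scatter, is expected, since compound 1 gives 290 nM while also carrying a bromo group. The expected step is a 3.0-fold lower number from compound 2 to compound 3 (0.48 log units; beyond the scatter). For compound 3 the estimated value in this assay is 500 nM, with a range from 200 nM to 1500 nM.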

Compound 3, concentration for 50% growth inhibition: 240 nM
The estimate for compound 3 lay 2.1-fold (0.32 log units) above the measured number, and the stated range covers the measured number.
By their numbers in this assay, from the lowest: compounds 3 and 1 (each within the scatter of the next); then compound 2.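

In this assay, within the data shown here, bromo in place of hydrogen on an aromatic carbon of the fused two-ring part gives a 6.3-fold lower number from compound 2 to compound 3 (0.80 log units; beyond the scatter), the first direct reading of this change, as these two compounds differ in that one place only. With bromo present, 4-methoxyphenyl in place of 2-hydroxyphenyl on a saturated ring carbon gives a 1.2-fold lower number from compound 1 to compound 3 (0.08 log units; within the scatter), so the gap between compound 1 and compound 2 is matched by the bromo step and not by the swap of those two groups. Nothing measured here accounts for the size of the bromo step.

As far as these compounds go, whether chloro, fluoro or an amine on the same carbon would give a similar step remains open. So does the size of the bromo step when 2-hydroxyphenyl sits on the saturated ring carbon.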